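Dropping the Phenyl End of a Long Side Chain

A few compounds are considered here, and "the series" means these few. Any claim that something is new, unique, unknown or untested is made for them only; others in the source may bear on it.

Measured in a physicochemical assay for solubility, read by HPLC, in phosphate buffer, measured as kinetic solubility, with a stated time of 1 h, at pH 7.4, tested at 250 uM; on this read-out higher numbers stand for higher solubility and lower numbers for lower solubility:
- compound 1 (`CCCCCNC(=O)n1c(=O)oc2cc(-c3ccc(F)cc3)ccc21`) gives < 1000 nM, a limit of the assay and not a number
- compound 2 (`CC(C)CNC(=O)n1c(=O)oc2cc(C3CCN(C)CC3)ccc21`) gives 240000 nM
- compound 3 (`CN1CCC(c2ccc3c(c2)oc(=O)n3C(=O)NCCCCc2ccccc2)CC1`) gives 120000 nM

Only compound 2 and compound 3 have true numbers here, and these two lie within the scatter of each other. The next compound, compound 4 (`CCCCCNC(=O)n1c(=O)oc2cc(C3CCN(C)CC3)ccc21`), has not been measured yet. It differs from compound 3 in one place: methyl in place of phenyl on a saturated chain carbon, four bonds along the chain from an amide-type nitrogen. Put simply, this is methyl in place of phenyl on a saturated chain carbon, four bonds along the chain from an amide-type nitrogen, and the same difference can be read as 3-phenylpropyl to butyl.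

Within the data shown here, one measured step bears on this change, because it also concerns a chain with and without a phenyl end: a 2.0-fold lower number from compound 2 to compound 3 (0.30 log units; within the scatter). That step runs the opposite way, adding the phenyl rather than removing it, and it did not leave the scatter. Going by that single step, no real shift is expected in this assay when the phenyl is removed. The estimated step is a 1.4-fold higher number from compound 3 to compound 4 (0.15 log units; within the scatter). For compound 4 the expected value is 170000 nM, with an estimated range from 90000 nM to 250000 nM.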

Compound 4, solubility: 240000 nM
Beside the measured number, compound 4's estimate is 1.4-fold (0.15 log units) below it; the range from low to high includes it.
By their numbers in this assay, from the lowest: compounds 3, 2 and 4 (each within the scatter of the next). At a limit, below all of these: compound 1.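

In this assay, methyl in place of phenyl on a saturated chain carbon, four bonds along the chain from an amide-type nitrogen, gives a 2.0-fold higher number from compound 3 to compound 4 (0.30 log units; within the scatter), and butyl in place of isopropyl on a saturated chain carbon bound to an amide-type nitrogen gives no change at the digits printed from compound 2 to compound 4 (within the scatter), so the three compounds that carry 1-methylpiperidin-4-yl on the shared core all lie within the scatter of each other, whether or not the chain ends in phenyl. Among these compounds, the only step here beyond the scatter lies at another place on the molecule, where 1-methylpiperidin-4-yl stands in place of 4-fluorophenyl on an aromatic carbon: an at least 240-fold higher number from compound 1 to compound 4 (2.38 log units; beyond the scatter). The value of compound 1 in that comparison is a limit of the assay and not a number: the limit of < 1000 nM in this assay, at which 1 of the 4 values shown sits.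

What a chain end carrying an amine or a carboxylic acid would read in this assay remains open, as does the reading for a chain much longer than those shown. Among the compounds shown here, also open is whether a phenyl at the chain end would count for more with 4-fluorophenyl on the aromatic carbon, since the only compound with that group carries no such phenyl.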